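Swapping bromo for hydrogen on a weak inhibitor

This account rests on a few compounds, and the source may have more. Where it says the series, first, only, none or still open, it means among the compounds named here.

In a functional assay on THP-1 cells (Homo sapiens) for inhibition, read by sulforhodamine B assay, with a stated time of 48 h (on this read-out lower numbers stand for stronger inhibition and higher numbers for weaker inhibition), compound 1 `COC(=O)[C@H]1C[C@@H](c2coc3ccccc3c2=O)N(c2ccccc2)O1` gives > 60000 nM as a limit of the assay and not a number. Within the data shown here, compound 2 `O=c1c([C@@H]2C[C@H](c3ccccc3)ON2c2ccccc2)coc2ccc(Br)cc12` gives 60000 nM as the only true number so far. Compound 3 `O=c1c([C@@H]2C[C@H](c3ccccc3)ON2c2ccccc2)coc2ccccc12` differs from compound 2 in one place, (hydrogen in place of bromo on an aromatic carbon), with hydrogen in place of bromo on an aromatic carbon. Among the measured compounds shown here, no measured pair shows what this change does. The expected change in this assay is no change at the digits printed from compound 2 to compound 3 (within the scatter) and no larger than the usual scatter, in either direction. For compound 3 the estimated value is 60000 nM within an expected range of 28000 nM to 120000 nM on this measure.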

Compound 3, half-maximal inhibitory concentration: > 60000 nM
Compound 3: a limit, no number; the forecaster's own chance of this, stated with the estimate: 55%; the middle value sits exactly at the limit.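

In this assay, hydrogen in place of bromo on this aromatic carbon gives a number no lower from compound 2 to compound 3 (the limit leaves the size open). Removing the bromo therefore brings no visible gain in inhibition, so the one true number among these compounds does not improve with this change. The size of this step cannot be read, and neither can the step between compound 1 and compound 3, because these values rest on a limit of the assay and not on a number: the limit of > 60000 nM in this assay, at which 2 of the 3 values shown sit.

On these data alone, it stays open whether an amine or a carboxylic acid on this aromatic carbon would give stronger inhibition.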